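Difluorophenyl in Place of Methoxyphenyl on the Cyclopropane

This account rests on a few compounds, and the source may have more. Where it says the series, first, only, none or still open, it means among the compounds named here.

Compound 1 `N[C@@H](CC1CCCCC1)CN(C(=O)[C@@H]1C[C@H]1c1ccccc1)c1ccc(-c2ccccc2)cc1` gives 1.7 nM in a functional assay for agonist activity at G protein-coupled receptor 88 (Homo sapiens), read by HTRF and cAMP accumulation (on this read-out higher numbers stand for an effect only at larger amounts of compound and lower numbers for an effect already at smaller amounts), and compound 2 `CC(C)(N)CN(C(=O)[C@@H]1C[C@H]1c1ccccc1)c1ccc(-c2ccccc2)cc1` gives 1.4 nM. The step of a 1.2-fold lower number from compound 1 to compound 2 (0.08 log units; within the scatter) touches only the amine-bearing chain. Compound 3 `CC[C@H](C)[C@H](N)CN(C(=O)[C@@H]1C[C@H]1c1ccc(OC)cc1)c1ccc(-c2ccccc2)cc1` sits at the limit of > 25000 nM in this assay, at which 1 of the 3 values shown sits, a limit of the assay rather than a number, reported as > 25000 nM. Compound 4 `CC[C@H](C)[C@H](N)CN(C(=O)[C@@H]1C[C@H]1c1c(F)cccc1F)c1ccc(-c2ccccc2)cc1` differs from compound 3 in one place: 2,6-difluorophenyl in place of 4-methoxyphenyl on a saturated ring carbon. Within the data shown here, no measured step changes this aryl group, so the single step on record does not bear on the change, and the outcome is open. Starting from a limit, compound 4 is expected to stay weak, with an at least 1.6-fold lower number from compound 3 to compound 4 (0.22 log units; that floor lies within the scatter) as the estimated step. Compound 4 is therefore estimated at 15000 nM, between 1000 nM and 25000 nM.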

Compound 4, half-maximal effective concentration: 11000 nM
The estimate for compound 4 lay 1.4-fold (0.13 log units) above the measured number, within the range that was stated.
By their numbers in this assay, from the lowest: compounds 2 and 1 (each within the scatter of the next); then compound 4. At a limit, above all of these: compound 3.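

This position responds to a change of aryl group in this assay: 2,6-difluorophenyl in place of 4-methoxyphenyl gives an at least 2.2-fold lower number from compound 3 to compound 4 (0.35 log units; beyond the scatter). Compound 3 stands at a limit of the assay, not at a number: the limit of > 25000 nM in this assay, at which 1 of the 4 values shown sits. Going by these compounds, the true size of the step therefore stays unknown, and only its lower bound can be read.

On these data alone, it remains open how a 4-chlorophenyl group would read on this saturated ring carbon. As far as these compounds go, it is also open whether the effect of 2,6-difluorophenyl would hold with a different amine-bearing chain.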